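The source may report more compounds than this note shows. Statements on the series, on what has been measured and on what is new or still open speak of the compounds shown alone.

Measured compounds:
compound 1 `c1ccc(COc2cccc(-c3cn([C@H]4CN5CCC4CC5)nn3)c2)cc1`: 5060 nM
compound 2 `c1ccc(COc2cccc(-c3cn([C@@H]4CN5CCC4CC5)nn3)c2)cc1`: 414 nM

In an assay on HEK293 cells for displacement of a labelled ligand from Neuronal acetylcholine receptor; alpha4/beta2 (Homo sapiens), read by scintillation counting, with a stated time of 120 min (on this read-out higher numbers stand for weaker inhibition and lower numbers for stronger inhibition), compound 1 gives 5060 nM, the higher of the two numbers shown; compound 2 gives 414 nM. Going by the values given here, the single measured step, a 12-fold lower number from compound 1 to compound 2 (1.09 log units; beyond the scatter), rests on the fact that one of compounds 1 and 2 is drawn with a defined configuration and the other without, at the place where they differ and concerns a stereocentre at a saturated ring carbon, not the chain on the aromatic oxygen.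

Compound 3 `FCCCOc1cccc(-c2cn([C@H]3CN4CCC3CC4)nn2)c1` differs from compound 1 by 2-fluoroethyl in place of phenyl on a saturated chain carbon bound to an oxygen on an aromatic ring, with the ring stereocentre drawn as in compound 1. Among the compounds with values here, no measured step touches the chain on the aromatic oxygen, so the size of the step to compound 3 cannot be read from the numbers in hand; the one comparison available alters a different part of the molecule. Nothing here gives grounds to expect a shift beyond the scatter in either direction in this assay. The estimate for compound 3 is 5000 nM, within 1000 nM to 25000 nM. The expected step is a 1.0-fold lower number from compound 1 to compound 3 (0.01 log units; within the scatter).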

Compound 3, inhibition constant: 9010 nM
Beside the measured number, compound 3's estimate is 1.8-fold (0.26 log units) below it, and the stated range covers the measured number.
By their numbers in this assay, from the lowest: compound 2; then compounds 1 and 3 (each within the scatter of the next).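

In this assay, going by these compounds alone, 3-fluoropropoxy in place of benzyloxy gives a 1.8-fold higher number from compound 1 to compound 3 (0.25 log units; within the scatter), the first reading at this position. In this one pair, then, the phenyl ring of the benzyl group can be exchanged for an open fluorinated chain without a change beyond the scatter, at least with the ring stereocentre drawn as in compound 1. Within the data shown here, nothing available speaks to the reason for this result, since the only supporting information concerns the stereocentre and not the chain on the aromatic oxygen.

Going by these compounds, it remains open whether the same exchange would read alike in the configuration of compound 2, which gives 414 nM. Also open, on these data alone, is how a longer alkyl chain, or an amine at the end of the chain, would read at this place.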